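Swapping dimethylamino for pyrrolidin-1-yl on compound 2

This account rests on a few compounds, and the source may have more. Where it says the series, first, only, none or still open, it means among the compounds named here.

Compound 1 `COc1cccc(/C=C/C(=O)c2ccc(OC)c3c2OC(C)(C)C=C3)c1` gives > 10000 nM (a limit)
Compound 2 `COc1ccc(C(=O)/C=C/c2ccc(N(C)C)cc2)c2c1C=CC(C)(C)O2` gives 570 nM (a number)

Both results come from a functional assay on SW-620 cells (Homo sapiens) for antiproliferative activity, read by MTT assay, with a stated time of 24 h (on this read-out higher numbers stand for weaker inhibition and lower numbers for stronger inhibition), and compound 1 sits at a limit of that test the limit of > 10000 nM in this assay, at which 1 of the 2 values shown sits, with no number of its own. Compound 2 therefore holds the only true number shown, so it has no measured neighbour to be ranked against. Compound 3 `COc1ccc(C(=O)/C=C/c2ccc(N3CCCC3)cc2)c2c1C=CC(C)(C)O2` differs from compound 2 in one place: pyrrolidin-1-yl in place of dimethylamino on an aromatic carbon (pyrrolidin-1-yl in place of dimethylamino on an aromatic carbon, para to a large group). Among the compounds with values here, the only measured step, an at least 17-fold lower number from compound 1 to compound 2 (1.24 log units; beyond the scatter), is large and beyond the scatter. It bears only loosely on this change: it swaps a whole substituted phenyl group, whereas compound 3 alters only the dimethylamino group. Compound 3 keeps the rest of compound 2 at 570 nM (its starting point), so no step beyond the scatter is expected in this assay here. The estimated change is a 1.3-fold lower number from compound 2 to compound 3 (0.10 log units; within the scatter) in size. For compound 3 the expected value is 450 nM with an estimated range from 130 nM to 1600 nM (four of five measurements).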

Compound 3, half-maximal inhibitory concentration: 7150 nM
Compound 3: middle estimate off by 16-fold (1.20 log units), on the low side, and the stated range ends below it.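

In this assay, replacing dimethylamino with pyrrolidin-1-yl gives a 13-fold higher number from compound 2 to compound 3 (1.10 log units; beyond the scatter), which shows that inhibition at this aromatic carbon, para to a large group, depends on more than the presence of a nitrogen. The two groups share the same counts of hydrogen-bond donors and acceptors and carry no net charge, yet the ring and its extra heavy atoms go with much weaker inhibition. Compound 1 sits at a limit of the test rather than at a number, so the test has an upper end: the limit of > 10000 nM in this assay, at which 1 of the 3 values shown sits.

These compounds cannot tell why the pyrrolidin-1-yl group costs so much. As far as these compounds go, it also remains open whether the open-chain diethylamino group or the six-membered piperidin-1-yl ring would behave like dimethylamino or like pyrrolidin-1-yl.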